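Propyl for bromo on the shared core: intrinsic activity

A few compounds are considered here, and "the series" means these few. Any claim that something is new, unique, unknown or untested is made for them only; others in the source may bear on it.

Measured so far:
compound 1 `CC(Oc1ccccc1OC1CC1)C1=NCCN1` — 0.7
compound 2 `CC(Oc1ccccc1Br)C1=NCCN1` — 0.87

In an assay on isolated protein for agonist activity at Alpha-2C adrenergic receptor (Homo sapiens) (a higher number here means a larger maximal response, a lower number a smaller maximal response), compound 1 gives 0.7 and compound 2 gives 0.87. Compound 2 thus stands highest of the two numbers measured; its nearest neighbour is compound 1, and the step a number 0.17 higher from compound 1 to compound 2 (beyond the scatter) lies beyond the scatter, a modest rise when bromo replaces cyclopropyloxy on an aromatic carbon.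

Compound 3 `CCCc1ccccc1OC(C)C1=NCCN1` has not yet been measured in this assay. It differs from compound 2 in one place: propyl in place of bromo on an aromatic carbon.

Going by the values given here, only one measured step exists, a number 0.17 higher from compound 1 to compound 2 (beyond the scatter), and it concerns a different exchange on the same aromatic carbon, so it bears on the new change only loosely. It shows that this position tolerates a change of substituent with a modest shift in the maximal response. Nothing measured shows what propyl does there. The account therefore expects, for compound 3, a step a number 0.070 lower from compound 2 to compound 3 (within the scatter) in this assay, within the scatter, and estimates the intrinsic activity of compound 3 at 0.8, in the range 0.6 to 0.95.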

Compound 3, intrinsic activity: the largest response reached, as a fraction of the reference agonist's: 0.75
Compound 3: middle estimate off by 0.050, on the high side, and the stated range covers the measured number.
By their numbers in this assay, from the lowest: compounds 1 and 3 (each within the scatter of the next); then compound 2.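

In this assay, the exchange of bromo for propyl on this aromatic carbon, ortho to a group of 8 heavy atoms, gives a number 0.12 lower from compound 2 to compound 3 (beyond the scatter), so a chain of 3 carbon atoms does not keep the maximal response seen with the single bromine atom. The second comparison adds something the first pair could not show: two quite different groups, propyl and cyclopropyloxy, cannot be told apart here, with a number 0.050 higher from compound 1 to compound 3 (within the scatter), and among these three compounds only compound 2, with bromo, stands clear of the others. Nothing available explains why bromo stands apart from propyl and cyclopropyloxy at this position.

With only three groups at this position, the compounds shown leave open whether the higher response belongs to bromo alone or would also appear with chloro or fluoro. They also leave open how the response would move with a shorter chain such as methyl, a longer chain such as butyl, or an amine on the same aromatic carbon of the shared core.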